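Methoxy for chloro on the six-membered ring of compound 2

The source may hold more compounds than are shown below. What is called first, only, known or untested is meant among the compounds shown, and "the series" means these compounds.

Of the compounds shown here, three built on one shared core have been measured in an assay on isolated protein for inhibition of Aromatase (Homo sapiens), read by ELISA, using NADPH, with a stated time of 24 h; on this read-out higher numbers stand for weaker inhibition and lower numbers for stronger inhibition. Compound 1 `Fc1ccc(-c2[nH]c3cc(F)ccc3c2Cn2ccnc2)cc1` gives 51.2 nM. Compound 2 `Fc1ccc2c(Cn3ccnc3)c(-c3ccc(Cl)cc3)[nH]c2c1` gives 82.9 nM, and compound 3 `Clc1ccc(-c2[nH]c3cc(Cl)ccc3c2Cn2ccnc2)cc1` gives 261 nM. Compound 2 thus holds the second highest of the three numbers: the step of a 1.6-fold higher number from compound 1 to compound 2 (0.21 log units; within the scatter) lies within the scatter, whereas the step of a 3.1-fold higher number from compound 2 to compound 3 (0.50 log units; beyond the scatter) is beyond it. Compound 4 `COc1ccc(-c2[nH]c3cc(F)ccc3c2Cn2ccnc2)cc1` is the next member; it differs from compound 2 by methoxy in place of chloro on an aromatic carbon. Among the measured compounds shown here, no measured step involves a methoxy group, so only indirect guidance exists. The step of a 1.6-fold higher number from compound 1 to compound 2 (0.21 log units; within the scatter) altered the same aromatic carbon of the six-membered aromatic ring of carbon only and stayed within the scatter, while a 3.1-fold higher number from compound 2 to compound 3 (0.50 log units; beyond the scatter) changed a different position and was modest. One therefore expects a small step in this assay, a 1.4-fold higher number from compound 2 to compound 4 (0.16 log units; within the scatter), leaning towards a higher number but not clearly beyond the scatter. Compound 4 is estimated at 120 nM, within the range 40 nM to 360 nM.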

Compound 4, half-maximal inhibitory concentration: 36.1 nM
For compound 4 the middle estimate is 3.3-fold (0.52 log units) above the measured one; measured number below the stated range.
By their numbers in this assay, from the lowest: compounds 4, 1 and 2 (each within the scatter of the next, the first and the last beyond it); then compound 3.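

In this assay, the change from 4-chlorophenyl to 4-methoxyphenyl gives a 2.3-fold lower number from compound 2 to compound 4 (0.36 log units; beyond the scatter), so this aromatic carbon, para to a large group, accepts methoxy, with its two heavy atoms and one hydrogen-bond acceptor, with no loss of inhibition against chloro. Set against fluoro at the same carbon, the change gives a 1.4-fold lower number from compound 1 to compound 4 (0.15 log units; within the scatter), so methoxy and fluoro cannot be told apart here. Chloro is separated from methoxy but not from fluoro, which the earlier step between compound 1 and compound 2 could not show on its own.

No evidence on offer accounts for the step from chloro to methoxy. The compounds shown leave open how an amine, a hydroxyl group or a longer chain such as ethoxy would fare at this carbon.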